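The source may hold more compounds than are shown below. What is called first, only, known or untested is meant among the compounds shown, and "the series" means these compounds.

Working notes on the series. Compound 1 `Nc1cccn2cc(Cc3ccccc3)c(=O)nc12` gives 131000 nM in a functional assay on HepG2 cells (Homo sapiens) for cytotoxicity, read by MTT assay, with a stated time of 24 h; on this read-out higher numbers stand for weaker inhibition and lower numbers for stronger inhibition. Compound 2 `Nc1cccn2cc(Cc3ccc(F)cc3)c(=O)nc12` reaches only a limit of this assay, > 1000000 nM, so its standing is known just as a bound (the limit of > 1000000 nM in this assay, at which 1 of the 2 values shown sits). Within the data shown here, the single measured step, an at least 7.6-fold higher number from compound 1 to compound 2 (0.88 log units; beyond the scatter), concerns a different position from the one now changed. Compound 3 `O=c1nc2ccccn2cc1Cc1ccc(F)cc1` differs from compound 2 by hydrogen in place of amino on an aromatic carbon. Among the measured compounds shown here, no measured step bears on this change, so no step beyond the scatter is expected, and compound 3 is expected to sit near the same limit, a step that the limit leaves unreadable from compound 2 to compound 3. The estimate for compound 3 is 1500000 nM, with a range from 300000 nM to 10000000 nM.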

Compound 3, half-maximal inhibitory concentration: > 1000000 nM
Compound 3: no number, only a limit; the forecaster's own chance of this, stated with the estimate: 70%; the middle value is on the limit's open side.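

Compound 2 and compound 3 both sit at a limit, so no step can be read between them: the limit of > 1000000 nM in this assay, at which 2 of the 3 values shown sit. The compounds shown leave open what hydrogen in place of amino on an aromatic carbon does to the read-out.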